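A few compounds are considered here, and "the series" means these few. Any claim that something is new, unique, unknown or untested is made for them only; others in the source may bear on it.

Three compounds have been taken through a physicochemical assay for acid dissociation, so far. Compound 1 `CCCCNC1=NCCCN1OCc1ccccc1` returned > 12 as a limit of the assay and not as a number. Compound 2 `CCCCCSC1=NCCN1OCc1ccccc1` gives 8.5 and compound 3 `CCCCCNC1=NCCN1OCCc1ccccc1` gives 9.9 as true numbers. Compound 3 therefore stands as the higher of the two numbers, and its gap to compound 2, its nearest neighbour, lies beyond the usual scatter. Compound 3 gives up its proton less readily than compound 2 does.

Compound 4 `CCCCCNC1=NCCN1OCCCc1ccccc1` has not yet been measured and differs from compound 3 in one place (benzyl in place of phenyl on a saturated chain carbon, two bonds along the chain from an oxygen). The change is benzyl in place of phenyl on a saturated chain carbon, two bonds along the chain from an oxygen.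

Going by the values given here, no two measured compounds differ in only one place, so the data give no direct measure of what such a change does. The starting point is therefore compound 3 at 9.9 and the expectation is of no shift beyond the scatter, in either direction. A small step of a number 0.10 log units higher from compound 3 to compound 4 (within the scatter) is what is expected here. In this assay the estimated value for compound 4 is 10 with an expected range from 9.5 to 10.5 as the likely span.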

Compound 4, acid dissociation constant: 10
Compound 4: middle estimate and measured number agree at the digits printed; measured number inside the range.
By their numbers in this assay, from the lowest: compound 2; then compounds 3 and 4 (each within the scatter of the next). At a limit, above all of these: compound 1.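

Putting benzyl in place of phenyl on a saturated chain carbon, two bonds along the chain from an oxygen, gives in this assay a step of a number 0.10 log units higher from compound 3 to compound 4 (within the scatter). Going by these compounds alone, this is the first direct reading of a single change in this set, since none of the earlier compounds formed a pair that differed in only one place, so their numbers could not separate one change from another. At this position, then, swapping phenyl for benzyl leaves the read-out where it was, and the two compounds cannot be told apart in this measurement, though that is one pair and one change and says nothing yet about any other position on the shared core.

On these data alone, whether a group of a different kind at this same position, such as an amine, a carboxylic acid or a longer chain without the aromatic ring, would also leave the number in place remains open. Compound 1 gives a limit and not a number, so the size of its distance from the other compounds cannot be read: the limit of > 12 in this assay, at which 1 of the 4 values shown sits.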